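The source may hold more compounds than are shown below. What is called first, only, known or untested is meant among the compounds shown, and "the series" means these compounds.

Compound 1 `N[C@H]1CC[C@H](C(=O)Nc2cc3cc[nH]c(=O)c3cc2Cl)CC1`: "not determined" (no result reported) in a functional assay (aorta) with Rattus norvegicus as the target; a higher number here means that more compound is needed for the effect, a lower number that less compound is needed
Compound 2 `CC(C)(C)C[C@@H](N)C(=O)Nc1cc2cc[nH]c(=O)c2cc1Cl`: "not determined" (no result reported) in this assay
Compound 3 `CC(C)C[C@@H](N)C(=O)Nc1cc2cc[nH]c(=O)c2cc1Cl`: 700 nM

All three share one core and carry an amide; they differ only in the group attached to the carbonyl carbon. In this assay compound 3 gives 700 nM. Among the compounds with values here, this is the single number available: for compound 1 and compound 2 nothing was reported, so compound 3 stands on its own, with no partner to compare against and no step between measured compounds to draw on.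

Compound 4 `CN1CCC(C(=O)Nc2cc3cc[nH]c(=O)c3cc2Cl)CC1` is the next case. Its difference from compound 3 is 1-methylpiperidin-4-yl in place of 1-amino-3-methylbutyl on a carbonyl carbon. The group that leaves is an open chain with one hydrogen-bond donor and one defined stereocentre; the group that enters is a six-membered non-aromatic ring with one hetero atom and no hydrogen-bond donor. Within the data shown here, nothing measured tells how large an effect such a swap has in this assay, so the expectation rests on the one number of compound 3 alone. A shift toward more compound being needed, or no change beyond the usual scatter, seems the most likely outcome, with wide uncertainty.

For compound 4 the estimate in this assay is 1200 nM, within a range of 250 nM to 6000 nM. The expected step is a 1.7-fold higher number from compound 3 to compound 4 (0.23 log units; within the scatter).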

Compound 4, half-maximal effective concentration: 250 nM
Compound 4: the middle estimate sits 4.8-fold (0.68 log units) above what was measured, within the range that was stated.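

In this assay, putting 1-methylpiperidin-4-yl in place of 1-amino-3-methylbutyl on a carbonyl carbon gives a 2.8-fold lower number from compound 3 to compound 4 (0.45 log units; beyond the scatter), a modest step that lies beyond the usual scatter and means that less compound is needed for the effect. Within the data shown here, this is the first sign that the result responds to what sits at this place, and it shows that the open chain, with its hydrogen-bond donor and defined stereocentre, is not required for activity in this pair: a six-membered non-aromatic ring without either feature does better. Nothing available explains why the step runs in this direction.

Among these compounds, the swap changes the ring, the donor count, the stereocentre and the heavy-atom count all at once, so this single step cannot show which of these differences matters, and no other measured pair is available to separate them. Going by these compounds, a plain piperidin-4-yl group, a cyclohexyl group or an open chain ending in a dimethylamino group could each help to separate them, but how any of these would behave here remains open.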